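Buffer stability: ethynyl, bromoacetyl and sulfanyl on one core

The source may report more compounds than this note shows. Statements on the series, on what has been measured and on what is new or still open speak of the compounds shown alone.

Measured compounds:
compound 1, `C#Cc1cc(C(F)(F)F)cc(C(F)(F)F)c1`, gives in an ADME assay for pharmacokinetics, read by LC-MS, in phosphate buffer, with a stated time of 72 h, at pH 7.4, tested at 250 uM (a higher number here means that the compound lasts longer, a lower number that the compound disappears faster), the value > 50 h, which is a limit of the assay.
compound 2, `O=C(CBr)c1cc(C(F)(F)F)cc(C(F)(F)F)c1`, gives in this assay the value < 0.017 h, also a limit of the assay.

Compound 2 stands at the lower limit of the two values shown, as the limit of < 0.017 h in this assay, at which 1 of the 2 values shown sits, records; compound 1 sits at the upper one, as the limit of > 50 h in this assay, at which 1 of the 2 values shown sits, records. For the measured compounds named here, the one measured step, an at least 2900-fold lower number from compound 1 to compound 2 (3.46 log units; beyond the scatter), runs between these two limits.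

Compound 3, `FC(F)(F)c1cc(S)cc(C(F)(F)F)c1`, is not yet measured. The change from compound 2 is sulfanyl in place of (bromomethyl)carbonyl on an aromatic carbon. Going by the values given here, it removes the (bromomethyl)carbonyl whose entry, on the same core, accompanied the large drop from compound 1 to compound 2, so a step back upward of comparable size is expected, well beyond the scatter, though the sulfanyl group has no precedent. Compound 3 is therefore expected to give about 30 h in this assay, within 6 h to 150 h, an estimated step of an at least 1700-fold higher number from compound 2 to compound 3 (3.24 log units; beyond the scatter).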

Compound 3, half-life: > 50 h
Compound 3 ended at the assay's limit (the forecaster's own chance of this, stated with the estimate: 40%); at least 1.6-fold (0.22 log units) between middle value and limit.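

At this position, on an aromatic carbon meta to two trifluoromethyl groups, sulfanyl in place of (bromomethyl)carbonyl gives an at least 2900-fold higher number from compound 2 to compound 3 (3.46 log units; beyond the scatter) in this assay, so a second group, besides ethynyl, now stands at the long-lasting end of the series. Among the three compounds on the shared core, only compound 2, with (bromomethyl)carbonyl, disappears fast: the limit of < 0.017 h in this assay, at which 1 of the 3 values shown sits. The step between compound 1 and compound 3 cannot be read, so ethynyl and sulfanyl cannot be ranked against each other, and both compounds rest on the same limit of the assay: the limit of > 50 h in this assay, at which 2 of the 3 values shown sit.

Open, on these data alone, is whether a plain acetyl group at this position, with the carbonyl kept and the bromine gone, would last like compound 3 or disappear like compound 2. Also open, as far as these compounds go, is how an amine or a carboxylic acid would behave here in this assay.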